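The source may hold more compounds than are shown below. What is called first, only, known or untested is meant among the compounds shown, and "the series" means these compounds.

Measured so far:
- compound 1 `COc1ccc(-c2nc(/N=C(\N)NC(C)C)sc2-c2ccc(OC)cc2)cc1`: 9.1 uM
- compound 2 `CNC(=O)NCc1nc(-c2ccc(OC)cc2)c(-c2ccc(OC)cc2)s1`: 15 uM

In a functional assay (aorta) with Rattus norvegicus as the target (on this read-out lower numbers stand for an effect already at smaller amounts and higher numbers for an effect only at larger amounts of compound), compound 2 gives 15 uM, and compound 1 gives 9.1 uM. Of the two numbers, compound 2 sits at the top, though only by a 1.6-fold higher number from compound 1 to compound 2 (0.22 log units; within the scatter), a gap within the scatter, so the two compounds cannot be told apart on this read-out.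

Compound 3 `COc1ccc(-c2nc(C3=CCN(C)CC3)sc2-c2ccc(OC)cc2)cc1` is not yet measured. It differs from compound 2 in one place: a group of 7 heavy atoms (6 carbon, 1 nitrogen; one six-membered non-aromatic ring with 1 hetero atom) in place of a group of 6 heavy atoms (3 carbon, 2 nitrogen, 1 oxygen; no ring), on an aromatic carbon.

Among the measured compounds shown here, the only measured step, a 1.6-fold higher number from compound 1 to compound 2 (0.22 log units; within the scatter), changes the same position of the shared core and stays within the scatter. For the measured compounds named here, nothing measured so far speaks to a ring entering at that place, so no step beyond the scatter is expected from compound 2 to compound 3 in this assay, and the estimate is a 1.7-fold lower number from compound 2 to compound 3 (0.22 log units; within the scatter).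

Compound 3 is therefore expected to give about 9 uM, most likely between 2.5 uM and 30 uM.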

Compound 3, concentration for half-maximal effect: 5.9 uM
Beside the measured number, compound 3's estimate is 1.5-fold (0.18 log units) above it; measured number inside the range.
By their numbers in this assay, from the lowest: compounds 3, 1 and 2 (each within the scatter of the next, the first and the last beyond it).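

In this assay, among the compounds shown here, this place on the five-membered aromatic ring shows, for the first time, a change beyond the scatter: swapping the ((methylcarbamoyl)amino)methyl group for a six-membered non-aromatic ring with 1 hetero atom gives a 2.5-fold lower number from compound 2 to compound 3 (0.41 log units; beyond the scatter), a modest step, and the entering group has 0 hydrogen-bond donors where the leaving group has 2. Replacing the open-chain group of compound 1 with the same ring gives a 1.5-fold lower number from compound 1 to compound 3 (0.19 log units; within the scatter), so this read-out does not separate those two groups. No measurement here explains either step.

Going by these compounds, it remains open whether the ring nitrogen matters, as a cyclohexenyl ring at this place would test. A simple primary amine or a carboxylic acid there could also shift the number in either direction.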